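The source may hold more compounds than are shown below. What is called first, only, known or untested is meant among the compounds shown, and "the series" means these compounds.

Compound 1 `O=C(O)C[C@@H]1CCCN1c1ccc(OCc2ccc(Cl)cc2Cl)cc1` gives 890 nM in an assay on HEK293 cells for binding affinity to Free fatty acid receptor 1 (Homo sapiens), read by scintillation counting and radioligand binding, with a stated time of 1 h; a higher number here means a weaker inhibitor, a lower number a stronger inhibitor.
Compound 2 `Cc1ccccc1Cc1ccc(N2CCC[C@H]2CC(=O)O)cc1` gives 1300 nM in this assay.
Compound 3 `O=C(O)C[C@@H]1CCCN1c1ccc(Oc2ccccc2F)cc1` gives 1300 nM in this assay.

Compound 2 stands level with compound 3 at the digits shown, and these two share the highest of the three numbers. The gap to compound 1 is within the scatter, so no order among the three compounds can be read from these figures; all three sit in one band.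

Compound 4 `Cc1ccccc1Cc1ccc(N2CC[C@H](C)[C@H]2CC(=O)O)cc1` differs from compound 2 by methyl in place of hydrogen on a saturated ring carbon. Among the measured compounds shown here, no pair of measured compounds differs in a single place, so there is no measured step to lean on, and the three numbers give no indication of a direction for a change on the saturated ring. The expected step is therefore small: the estimate means no change at the digits printed from compound 2 to compound 4 (within the scatter), none beyond the scatter. On this basis compound 4 is estimated at 1300 nM, with a range from 400 nM to 4000 nM in this assay.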

Compound 4, inhibition constant: 310 nM
Beside the measured number, compound 4's estimate is 4.2-fold (0.62 log units) above it; the measured number lies below the stated range.
By their numbers in this assay, from the lowest: compound 4; then compounds 1, 2 and 3 (each within the scatter of the next).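

Among the compounds shown here, the saturated ring carbon next to the ring atom that bears a carboxymethyl group is the first place where a single change can be read: in this assay, methyl in place of hydrogen gives a 4.2-fold lower number from compound 2 to compound 4 (0.62 log units; beyond the scatter). For the compounds shown here, the step lies beyond the scatter, so this position responds to the addition of 1 heavy atom, something the three earlier compounds, with no single-place step among them, could not show. No measurement shown explains why this step occurs.

On these data alone, whether ethyl, hydroxyl or an amine on the same carbon would move the number further, and how the opposite configuration of the methyl would read, stays open. Also open, as far as these compounds go, is whether the same methyl gives a similar step on the cores of compound 1 and compound 3.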